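Removing the aminomethyl arm from a bradykinin antagonist

The compounds below may be only part of what the source reports. "The series", "measured", "known", "first", "only" and "open" are said of these compounds alone.

Compound 3 `Cc1ccc(S(=O)(=O)N2C=CNC(=O)[C@H]2CC(=O)N[C@@H]2CCCc3cc(CN4CCCC4)ccc32)cc1` has the lowest number of the three compounds in an in vitro functional assay on cells for antagonist activity at B1 bradykinin receptor (Homo sapiens), read by luminescence and calcium flux, with a stated time of 2 h (a higher number here means a weaker inhibitor, a lower number a stronger inhibitor), with 0.084 nM. Compound 1 `Cc1ccc(S(=O)(=O)N2C=CNC(=O)[C@H]2CC(=O)N[C@@H]2CCCc3cc(CN4CCCCC4)ccc32)cc1` gives 0.115 nM, and compound 2 `Cc1ccc(S(=O)(=O)N2C=CNC(=O)[C@H]2CC(=O)N[C@@H]2CCCc3cc(CN(C)C)ccc32)cc1` gives 0.21 nM. The steps among them are a 1.4-fold lower number from compound 1 to compound 3 (0.14 log units; within the scatter), a 1.8-fold higher number from compound 1 to compound 2 (0.26 log units; within the scatter) and a 2.5-fold lower number from compound 2 to compound 3 (0.40 log units; beyond the scatter). Compound 4 `Cc1ccc(S(=O)(=O)N2C=CNC(=O)[C@H]2CC(=O)N[C@@H]2CCCc3ccccc32)cc1` arises from compound 3 by hydrogen in place of (pyrrolidin-1-yl)methyl on an aromatic carbon. The measured steps only exchange one amine for another and shift the number little; none removes the group altogether, so they bear on this change weakly. The whole arm is lost here, and a clearly higher number is expected, a 60-fold higher number from compound 3 to compound 4 (1.77 log units; beyond the scatter). Compound 4 is therefore estimated at 5 nM, within 0.4 nM to 60 nM.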

Compound 4, half-maximal inhibitory concentration: 3.3 nM
Beside the measured number, compound 4's estimate is 1.5-fold (0.18 log units) above it; low and high end bracket the measured number.
By their numbers in this assay, from the lowest: compounds 3, 1 and 2 (each within the scatter of the next, the first and the last beyond it); then compound 4.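

In this assay removal of the arm gives a 39-fold higher number from compound 3 to compound 4 (1.59 log units; beyond the scatter) together with a 29-fold higher number from compound 1 to compound 4 (1.46 log units; beyond the scatter) and a 16-fold higher number from compound 2 to compound 4 (1.20 log units; beyond the scatter) and so outweighs any exchange of one amine for another. On this aromatic carbon, having such an arm at all counts for far more than which of these three amines it carries, though compound 4 still gives 3.3 nM without one. Going by these compounds, whether the amine nitrogen itself is what matters stays open, and a hydroxymethyl or a plain propyl group on this carbon would help to tell. Nothing given here explains the loss.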